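Fluoroallylamine series: aromatic substituent changes

This account rests on a few compounds, and the source may have more. Where it says the series, first, only, none or still open, it means among the compounds named here.

Measured so far:
compound 1 `COc1ccc(OC/C(F)=C\CN)cc1`: 310 nM
compound 2 `CC(C)(C)c1ccc(OC/C(F)=C\CN)cc1`: 6400 nM

Both were run in an assay on isolated protein for inhibition of Amine oxidase [flavin-containing] B (Homo sapiens), read by Amplex Red; on this read-out lower numbers stand for stronger inhibition and higher numbers for weaker inhibition. Among the measured compounds shown here, compound 1 gives the lowest of the two numbers; its nearest neighbour is compound 2, and the step of a 21-fold higher number from compound 1 to compound 2 (1.31 log units; beyond the scatter) is large and beyond the scatter, the only measured step in the set.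

Compound 3 `NC/C=C(/F)COc1ccc(C(N)=O)cc1` is not yet measured. It differs from compound 1 by carbamoyl in place of methoxy on an aromatic carbon. For the measured compounds named here, no measured step covers a carbamoyl group; the single known step concerns tert-butyl, a group unlike carbamoyl in what it carries, so it gives only a loose guide that changing the methoxy position can cost much. The expectation is therefore a modest weakening, smaller than the tert-butyl step, with wide uncertainty: the estimated step is a 1.9-fold higher number from compound 1 to compound 3 (0.29 log units; within the scatter). Compound 3 is expected to give about 600 nM, with a range from 120 nM to 3000 nM.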

Compound 3, half-maximal inhibitory concentration: > 30000 nM
Compound 3 ended at the assay's limit; the forecaster's own chance of this, stated with the estimate: 5%; middle value at least 50-fold (1.69 log units) from the limit.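

The value for compound 3 is a limit of the assay and not a number: the limit of > 30000 nM in this assay, at which 1 of the 3 values shown sits.

With carbamoyl on this aromatic carbon, para to a group of 7 heavy atoms, the step is an at least 96-fold higher number from compound 1 to compound 3 (1.98 log units; beyond the scatter), so this position can lose far more than the tert-butyl change alone showed. Carbamoyl also falls short of tert-butyl, at an at least 4.6-fold higher number from compound 2 to compound 3 (0.67 log units; beyond the scatter), which makes tert-butyl no longer the poorest of the replacements for methoxy shown here.

How far compound 3 lies past the limit cannot be read, and the three compounds do not separate the hydrogen-bond donor that carbamoyl brings from the other differences between the groups. Also open, going by these compounds, is whether a nitrile, which has no amide hydrogen, or a small group such as ethoxy or chlorine would stay nearer to methoxy.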